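The source may hold more compounds than are shown below. What is called first, only, known or untested is meant among the compounds shown, and "the series" means these compounds.

Three compounds share one core, a triazole-bearing carbamodithioate linked to a piperazine, and differ only in what caps the piperazine or the aryl group. Compound 1 `COc1ccc(Cn2cc(CSC(=S)N3CCNCC3)nn2)cc1` carries an unsubstituted piperazine, and in a functional assay on MGC-803 cells (Homo sapiens) for inhibition, read by MTT assay, with a stated time of 72 h (a higher number here means a weaker inhibitor, a lower number a stronger inhibitor), compound 1 gives "not determined" (no result reported). Compound 2 `COc1ccc(Cn2cc(CSC(=S)N3CCN(C(=O)OCc4ccccc4)CC3)nn2)cc1` carries a benzyl carbamate on that piperazine and gives 23800 nM. Compound 3 `COc1ccc(Cn2cc(CSC(=S)N3CCN(C(=O)OC(C)(C)C)CC3)nn2)cc1` carries a tert-butyl carbamate instead and gives 22800 nM. Among the two compounds with a number, compound 3 has the lowest, but the step of a 1.0-fold lower number from compound 2 to compound 3 (0.02 log units; within the scatter) is within the scatter, so the two cannot be ranked.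

Compound 4 `Cc1ccc(Cn2cc(CSC(=S)N3CCN(C(=O)OC(C)(C)C)CC3)nn2)cc1` keeps the tert-butyl carbamate of compound 3 and changes the aryl substituent: methyl in place of methoxy on an aromatic carbon. Among the compounds with values here, no measured step addresses this part of the molecule; the only measured step, from compound 2 to compound 3, concerns the carbamate and was flat. With nothing to suggest that the aryl substituent is sensitive here, the expected step of a 1.0-fold lower number from compound 3 to compound 4 (0.02 log units; within the scatter) is none beyond the scatter. Compound 4 is therefore estimated at 22000 nM in this assay, with a range from 9000 nM to 55000 nM.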

Compound 4, half-maximal inhibitory concentration: 3490 nM
For compound 4 the middle estimate is 6.3-fold (0.80 log units) above the measured one, and the stated range ends above it.
By their numbers in this assay, from the lowest: compound 4; then compounds 3 and 2 (each within the scatter of the next).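

In this assay, within the data shown here, the substituent on the aromatic ring matters: methyl in place of methoxy gives a 6.5-fold lower number from compound 3 to compound 4 (0.82 log units; beyond the scatter) and moves the series beyond the scatter, whereas the only earlier step, a 1.0-fold lower number from compound 2 to compound 3 (0.02 log units; within the scatter) at the carbamate, was flat. The position, para to a large group, therefore responds to a small edit, going from 4-methoxybenzyl to 4-methylbenzyl, with methoxy counting 2 heavy atoms and 1 hydrogen-bond acceptor and methyl counting 1 heavy atom and 0 hydrogen-bond acceptors. Nothing measured here says which of these differences, if either, lies behind the lower number.

With only methoxy and methyl shown at this position, it remains open whether a chlorine atom, an amine, a hydroxyl group or a longer chain such as ethyl would lower the number further, or whether a plain hydrogen would serve as well. It also remains open whether the same swap would lower the number with the benzyl carbamate of compound 2 on the piperazine, for the step is shown only with the tert-butyl carbamate.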